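Working notes: from compound 3 to compound 4

The source may report more compounds than this note shows. Statements on the series, on what has been measured and on what is new or still open speak of the compounds shown alone.

Of the compounds shown here, three have been read so far in an ADME assay on T29 cells (Homo sapiens) for cytotoxicity, read by sulforhodamine B assay, with a stated time of 3 days; a lower number here means a stronger inhibitor, a higher number a weaker inhibitor. Compound 1 `O=Cc1cn(Cc2ccc(Cl)cc2)c2cc(F)ccc12` gives > 31600 nM, which is a limit of the assay and not a number. Compound 2 `OCc1cn(Cc2ccc(Br)cc2)c2ccccc12` gives > 31600 nM, which is again a limit. Compound 3 `OCCc1cn(Cc2ccc(Cl)cc2)c2ccccc12` gives > 31600 nM, also a limit. Compound 3 therefore holds no rank of its own within the set, which stands at the limit of > 31600 nM in this assay, at which 3 of the 3 values shown sit.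

The next compound to be read is compound 4 `COC(=O)CNCc1cn(Cc2ccc(Cl)cc2)c2ccccc12`. The structural change is ((methoxycarbonyl)methyl)amino in place of hydroxymethyl on a saturated chain carbon bound to an aromatic carbon, with ((methoxycarbonyl)methyl)amino in place of hydroxymethyl on a saturated chain carbon bound to an aromatic carbon. Cut one bond further out, the same difference reads 2-hydroxyethyl to (((methoxycarbonyl)methyl)amino)methyl.

For the measured compounds named here, no two measured compounds differ in one place only, so this change has no direct precedent in this assay. A modest step toward stronger inhibition is expected, or none beyond the scatter, and the reading may well remain a limit. That expectation rests on compound 3, which gives > 31600 nM, a limit. The estimated move is an at least 1.2-fold lower number from compound 3 to compound 4 (0.10 log units; that floor lies within the scatter). The expected value for compound 4 is 25000 nM, with an estimated range from 8000 nM to 60000 nM.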

Compound 4, half-maximal inhibitory concentration: 31600 nM
Estimate against measurement, compound 4: 1.3-fold (0.10 log units) below; the range from low to high includes it.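

In this assay, for the compounds shown here, compound 4 gives 31600 nM, the first reading that is a number and not a limit, so a side chain carrying ((methoxycarbonyl)methyl)amino on a saturated chain carbon bound to an aromatic carbon can give a readable value here. Compound 3 gives > 31600 nM, which is a limit. Placing ((methoxycarbonyl)methyl)amino where hydroxymethyl stood gives a number no higher from compound 3 to compound 4 (the limit leaves the size open), so this position now has a direction for this change but no size, and the reading of compound 4 shows no strong inhibition in this assay.

The series as shown remains close to the end of the readable range, and little can yet be told apart: the limit of > 31600 nM in this assay, at which 3 of the 4 values shown sit. It remains open whether the ester matters or the amine alone carries the reading, which a free carboxylic acid in place of the methyl ester, a simple secondary amine or a longer chain at this position would help to separate, and whether any such group would move the number clearly lower than compound 4.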